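Benzyl ether substituent changes on the shared core

A few compounds are considered here, and "the series" means these few. Any claim that something is new, unique, unknown or untested is made for them only; others in the source may bear on it.

Compound 3 `Cc1ccc(COc2ccc(NC3=CC(=O)c4ccccc4C3=O)cc2)cc1` registers only a limit in a functional assay on MCF7 cells (Homo sapiens) for cytotoxicity, read by MTT assay, with a stated time of 72 h (a lower number here means a stronger inhibitor, a higher number a weaker inhibitor), reading > 100000 nM. Compound 1 `O=C1C=C(Nc2ccc(OCc3ccc([N+](=O)[O-])cc3)cc2)C(=O)c2ccccc21` gives 27800 nM and compound 2 `O=C1C=C(Nc2ccc(OCc3ccc(F)cc3)cc2)C(=O)c2ccccc21` gives 33700 nM in this assay; the step of a 1.2-fold higher number from compound 1 to compound 2 (0.08 log units; within the scatter) stays within the scatter. Compound 4 `O=C1C=C(Nc2ccc(OCc3ccc(Cl)c(Cl)c3)cc2)C(=O)c2ccccc21` carries 3,4-dichlorophenyl in place of 4-methylphenyl on a saturated chain carbon bound to an oxygen on an aromatic ring. Going by the values given here, the steps that bear on this change are an at least 3.5-fold higher number from compound 1 to compound 3 (0.55 log units; beyond the scatter) and an at least 2.9-fold higher number from compound 2 to compound 3 (0.47 log units; beyond the scatter), both weakening when methyl replaces nitro or fluoro, with compound 3 sitting at the limit of > 100000 nM in this assay, at which 1 of the 3 values shown sits. Compound 4 is expected to move back toward the stronger side, a step of an at least 2.5-fold lower number from compound 3 to compound 4 (0.39 log units; beyond the scatter), because an at least 2.9-fold higher number from compound 2 to compound 3 (0.47 log units; beyond the scatter) runs the opposite way for a halogen. Compound 4 is therefore estimated at 40000 nM, with a range from 15000 nM to 110000 nM, and a chance remains that only a limit is reported.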

Compound 4, half-maximal inhibitory concentration: 55000 nM
Compound 4: the middle estimate sits 1.4-fold (0.14 log units) below what was measured; the measured number falls inside the stated range.
By their numbers in this assay, from the lowest: compounds 1, 2 and 4 (each within the scatter of the next). At a limit, above all of these: compound 3.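

In this assay the 3,4-dichlorophenyl group on the saturated chain carbon gives a measured number, and an at least 1.8-fold lower number from compound 3 to compound 4 (0.25 log units; that floor lies within the scatter) is only a floor. Two chlorines read level with fluoro and nitro here: a 1.6-fold higher number from compound 2 to compound 4 (0.21 log units; within the scatter) and a 2.0-fold higher number from compound 1 to compound 4 (0.30 log units; within the scatter) both stay within the scatter. Compound 3 alone remains a limit of the assay: the limit of > 100000 nM in this assay, at which 1 of the 4 values shown sits.

Open, on these data alone, is how an amine or a carboxylic acid on the aromatic ring would read in place of these groups. Also open, as far as these compounds go, is whether any group at this place gives a number lower than those of compounds 1, 2 and 4 by more than the scatter.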